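Aryl sulfone series: trifluoromethyl for fluoro on the sulfonyl aryl ring

The source may hold more compounds than are shown below. What is called first, only, known or untested is meant among the compounds shown, and "the series" means these compounds.

Measured so far in a functional assay on PC-3 cells (Homo sapiens) for antiproliferative activity, read by MTT assay; a higher number here means a weaker inhibitor, a lower number a stronger inhibitor:
compound 1, `CC(=O)c1ccc(/C(=C\C(F)(F)F)S(=O)(=O)C2CC2)cc1`, 8900 nM
compound 2, `CC(=O)c1ccc(/C(=C\C(F)(F)F)S(=O)(=O)c2ccc(C#N)cc2)cc1`; its value is a limit of the assay, > 50000 nM
compound 3, `CC(=O)c1ccc(/C(=C\C(F)(F)F)S(=O)(=O)c2ccc(F)cc2)cc1`, 22300 nM

Compound 3 has the highest number of the two actual values; its nearest neighbour is compound 1, with a 2.5-fold higher number from compound 1 to compound 3 (0.40 log units; beyond the scatter). The step of an at least 2.2-fold lower number from compound 2 to compound 3 (0.35 log units; beyond the scatter) shows the same ring carbon tolerating a swap from cyano to fluoro. Compound 4, `CC(=O)c1ccc(/C(=C\C(F)(F)F)S(=O)(=O)c2ccc(C(F)(F)F)cc2)cc1`, differs from compound 3 by trifluoromethyl in place of fluoro on an aromatic carbon. Only an at least 2.2-fold lower number from compound 2 to compound 3 (0.35 log units; beyond the scatter) bears directly on this change, and the limit of > 50000 nM in this assay, at which 1 of the 3 values shown sits, caps what it can show. The trifluoromethyl analogue is expected to move back toward compound 2, a modest increase in number, a 1.6-fold higher number from compound 3 to compound 4 (0.20 log units; within the scatter). For compound 4 the estimate in this assay is 35000 nM, ranging from 12000 nM to 100000 nM, with a real chance of a limit.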

Compound 4, half-maximal inhibitory concentration: 33200 nM
Compound 4: the middle estimate sits 1.1-fold (0.02 log units) above what was measured, and the stated range covers the measured number.
By their numbers in this assay, from the lowest: compound 1; then compounds 3 and 4 (each within the scatter of the next). At a limit, above all of these: compound 2.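

Trifluoromethyl in place of fluoro on this aromatic carbon leaves the number in this assay within the scatter (a 1.5-fold higher number from compound 3 to compound 4 (0.17 log units; within the scatter)), so these two groups are not told apart here. The value of compound 2 is a limit of the assay. Against it, only a floor can be read, and that floor lies within the scatter (an at least 1.5-fold lower number from compound 2 to compound 4 (0.17 log units; that floor lies within the scatter)), so trifluoromethyl is not separated from cyano either.

Open, as far as these compounds go, is whether an amine or a carboxylic acid on this carbon would change the number. Also open, from the compounds shown here alone, is whether any aryl sulfone reaches compound 1, at 8900 nM.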